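Series notes: the step from compound 3 to compound 4

The compounds below may be only part of what the source reports. "The series", "measured", "known", "first", "only" and "open" are said of these compounds alone.

In an ADME assay on HL-60 cells (Homo sapiens) for cytotoxicity, read by resazurin assay, with a stated time of 72 h (a higher number here means that more compound is needed for the effect, a lower number that less compound is needed), compound 3 (`NCCCCCCC(=O)Nc1nc2ccc(C(=O)c3ccccc3)cc2[nH]1`) gives > 30000 nM, which is a limit and not a number. Compound 1 (`NCCCCNC(=O)Nc1nc2ccc(C(=O)c3ccccc3)cc2[nH]1`) gives > 30000 nM, also a limit. Compound 2 (`O=C(NCCCCO)Nc1nc2ccc(C(=O)c3ccccc3)cc2[nH]1`) gives > 30000 nM, again a limit. Compound 3 therefore shares (the limit of > 30000 nM in this assay, at which 3 of the 3 values shown sit).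

Compound 4 (`O=C(CCC1CCNCC1)Nc1nc2ccc(C(=O)c3ccccc3)cc2[nH]1`) carries piperidin-4-yl in place of 4-aminobutyl on a saturated chain carbon, two bonds along the chain from a carbonyl carbon.

Among the measured compounds shown here, two measured steps touch the chain of compound 3, yet neither offers a size to carry over: a step that the two limits leave unreadable from compound 1 to compound 3 and a step that the two limits leave unreadable from compound 2 to compound 3. The series has no measured number below the limit, so no direction can be drawn from it. In this assay no step beyond the scatter is expected, and the estimated step is a number no higher from compound 3 to compound 4 (the limit leaves the size open). For compound 4 the expected value is 30000 nM, with an estimated range from 12000 nM to 60000 nM, and a report of only a limit is the likeliest outcome.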

Compound 4, half-maximal effective concentration: > 30000 nM
Compound 4 ended at the assay's limit (the forecaster's own chance of this, stated with the estimate: 80%); the middle value lies on the limit itself.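

In this assay compound 4 gives > 30000 nM, again a limit and not a number. The steps linking compound 4 with compound 1, compound 2 and compound 3 cannot be read. The compounds shown leave open whether piperidin-4-yl and 4-aminobutyl differ at all in this cytotoxicity read-out.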